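Ring size of the basic amine in the propoxy side chain

This account rests on a few compounds, and the source may have more. Where it says the series, first, only, none or still open, it means among the compounds named here.

Measured so far:
Compound 1, `COc1cc2nc(-c3ccc(C(F)(F)F)cc3)cc(OCCCN3CCCCC3)c2cc1OC`: 454 nM
Compound 2, `COc1cc2nc(-c3ccc(Cl)cc3)cc(OCCCN3CCCCC3)c2cc1OC`: 1310 nM

In a functional assay on T47D cells (Homo sapiens) for inhibition, read by sulforhodamine B assay, with a stated time of 48 h (a higher number here means a weaker inhibitor of growth, a lower number a stronger inhibitor of growth), compound 1 gives the lowest of the two numbers; its nearest neighbour is compound 2, with a 2.9-fold higher number from compound 1 to compound 2 (0.46 log units; beyond the scatter), a change that sits on the aromatic carbon and not on the side chain.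

Compound 3, `COc1cc2nc(-c3ccc(C(F)(F)F)cc3)cc(OCCCN3CCCC3)c2cc1OC`, is not yet measured. It differs from compound 1 by pyrrolidin-1-yl in place of piperidin-1-yl on a saturated chain carbon, three bonds along the chain from an oxygen on an aromatic ring. Going by the values given here, no measured step bears on this change: the only step known, from compound 1 to compound 2, concerns the aromatic substituent and says nothing about the amine ring. Among the compounds with values here, with no step in hand, the expectation for compound 3 in this assay is a number close to that of compound 1, with no step beyond the scatter, and the estimated step of a 1.0-fold lower number from compound 1 to compound 3 (0.00 log units; within the scatter) reflects that. Compound 3 is therefore estimated at 450 nM, with a range from 180 nM to 1100 nM.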

Compound 3, concentration for 50% growth inhibition: 472 nM
Estimate against measurement, compound 3: 1.0-fold (0.02 log units) below, and the stated range covers the measured number.
By their numbers in this assay, from the lowest: compounds 1 and 3 (each within the scatter of the next); then compound 2.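

In this assay, going by these compounds alone, 3-(pyrrolidin-1-yl)propyl in place of 3-(piperidin-1-yl)propyl gives a 1.0-fold higher number from compound 1 to compound 3 (0.02 log units; within the scatter), the first reading on the side chain rather than on the aromatic substituent. With trifluoromethyl on the aromatic ring, the five-membered and six-membered amine rings therefore cannot be told apart in this growth read-out, so this ring-size change does not register here, whereas the chloro for trifluoromethyl change does. No measurement in hand offers an explanation for this result.

Open, from the compounds shown here alone, is whether the same holds with chloro on the aromatic ring, or for other amines at this position, such as morpholin-4-yl, azepan-1-yl or an open-chain dimethylamino group. Also open, going by these compounds, is how a shorter or longer chain between the oxygen and the amine would read.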